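The compounds below may be only part of what the source reports. "The series", "measured", "known", "first", "only" and "open" are said of these compounds alone.

Measured so far in an ADME assay (liver) for metabolic stability, with Liver microsome (Homo sapiens) as the target, read by LC-MS, using microsomes and NADPH, with a stated time of 5 min, at 37 degrees C; on this read-out lower numbers stand for slow clearance and higher numbers for fast clearance:
compound 1 `CCn1c([C@@H](C)NS(=O)(=O)c2ccccc2)nc2ccc(C(F)(F)F)cc21` gives 14 mL.min-1.g-1;
compound 3 `CCn1cc(S(=O)(=O)N[C@H](C)c2nc3ccc(C(F)(F)F)cc3n2CC)cn1` gives 95 mL.min-1.g-1.
For compound 2 `CCn1c([C@@H](C)NS(=O)(=O)c2ccc(C)cc2)nc2ccc(C(F)(F)F)cc21` the read-out in this assay is only a limit, > 100 mL.min-1.g-1, namely (the limit of > 100 mL.min-1.g-1 in this assay, at which 1 of the 3 values shown sits).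

From compound 1 to compound 2 the change is methyl in place of hydrogen on an aromatic carbon. The two cores differ as 1-ethyl-1H-pyrazol-4-yl in place of phenyl on a sulfonyl sulfur, with a 6.8-fold higher number from compound 1 to compound 3 (0.83 log units; beyond the scatter). Compound 2 against compound 3 shows an at least 1.0-fold lower number from compound 2 to compound 3 (0.02 log units; that floor lies within the scatter).

Compound 4 `CCn1ncc(S(=O)(=O)N[C@H](C)c2nc3ccc(C(F)(F)F)cc3n2CC)c1C` is not yet measured. Against compound 3 the difference is methyl in place of hydrogen on an aromatic carbon. This is the same kind of change as from compound 1 to compound 2, not the same: there the place is on an aromatic carbon of a six-membered aromatic ring of carbon only, para to a large group; here it is on an aromatic carbon of a five-membered aromatic ring with 2 nitrogen, next to the ring nitrogen, next to the ring atom that bears a large group, next to the ring atom that bears an ethyl group, two ring bonds from the ring nitrogen. Beside the earlier step, an at least 7.1-fold higher number from compound 1 to compound 2 (0.85 log units; beyond the scatter), the expected step is a 1.7-fold higher number from compound 3 to compound 4 (0.23 log units; within the scatter). Compound 4 is therefore estimated at 160 mL.min-1.g-1 in this assay, roughly 70 mL.min-1.g-1 to 400 mL.min-1.g-1, and will most likely come back as a limit.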

Compound 4, intrinsic clearance in microsomes: > 100 mL.min-1.g-1
Compound 4: a limit, no number (the forecaster's own chance of this, stated with the estimate: 65%); the middle value lies beyond the limit too.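

Compound 4 reads only as a limit in this assay, so the step on this core is a floor: an at least 1.0-fold higher number from compound 3 to compound 4 (0.02 log units; that floor lies within the scatter). Relative to the core of compound 1, the exchange on the sulfonyl sulfur gives an at least 7.1-fold higher number from compound 1 to compound 4 (0.85 log units; beyond the scatter), while the step between the two limits cannot be read. Methyl in place of hydrogen on an aromatic carbon gives a limit on both cores, and no lower number appears on either, but whether the size of the step carries over stays unknown: the same change on two cores in this assay, an at least 7.1-fold higher number (0.85 log units; beyond the scatter) from compound 1 to compound 2 and an at least 1.0-fold higher number (0.02 log units; that floor lies within the scatter) from compound 3 to compound 4; the limit leaves it open whether they differ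

The compounds shown leave open how far the clearance number lies past the limit for either methyl compound. Also open, from the compounds shown here alone, is whether chloro or methoxy in place of that methyl would give a readable number in this assay.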